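Carboxy to Hydrogen: Expected Paw Edema Inhibition of Compound 4

This account rests on a few compounds, and the source may have more. Where it says the series, first, only, none or still open, it means among the compounds named here.

Compound 1, `COc1ccc(-n2nc(C(=O)Nc3cccc(F)c3)nc2-c2cc(OC)c(OC)c(OC)c2)cc1`, gives 48% in a functional assay on the whole organism for inhibition, with Rattus norvegicus as the target, read by paw edema, with stated times of 30 min and 1 h, at a dose of 0.28 mmol/kg by the oral route; a higher number here means more inhibition at the dose given (going by the name of the read-out), a lower number less inhibition.
Compound 2, `COc1ccc(-n2nc(C(=O)Nc3ccc(C(F)(F)F)cc3)nc2-c2cc(OC)c(OC)c(OC)c2)cc1`, gives 48%.
Compound 3, `COc1ccc(-n2nc(C(=O)Nc3ccc(C(=O)O)cc3)nc2-c2cc(OC)c(OC)c(OC)c2)cc1`, gives 50%.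

Compound 3 holds the highest of the three numbers, yet the steps of a number 2 percentage points higher from compound 1 to compound 3 (within the scatter) and a number 2 percentage points higher from compound 2 to compound 3 (within the scatter) are both within the scatter, so its number cannot be called higher than the other two. Compound 4, `COc1ccc(-n2nc(C(=O)Nc3ccccc3)nc2-c2cc(OC)c(OC)c(OC)c2)cc1`, differs from compound 3 in one place: hydrogen in place of carboxy on an aromatic carbon. Among the measured compounds shown here, no measured step replaces a group by hydrogen; the three measured steps all exchange one group for another on the same aryl ring, and none moved the number beyond the scatter: no change at the digits printed from compound 1 to compound 2 (within the scatter), a number 2 percentage points higher from compound 1 to compound 3 (within the scatter), a number 2 percentage points higher from compound 2 to compound 3 (within the scatter). A step of a number 2 percentage points lower from compound 3 to compound 4 (within the scatter) is therefore expected, none beyond the scatter. Compound 4 is estimated at 48%, with a range from 36% to 60%.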

Compound 4, a percentage reported as inhibition, in the whole organism at one dose (the size of the read-out at that dose, not a potency): 45%
Estimate against measurement, compound 4: 3 percentage points above, and the stated range covers the measured number.
By their numbers in this assay, from the lowest: compounds 4, 1, 2 and 3 (each within the scatter of the next).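

Taking the substituent off the aryl ring altogether, a change no earlier step made, still leaves the number in this assay within the scatter (a number 5 percentage points lower from compound 3 to compound 4 (within the scatter); a number 3 percentage points lower from compound 2 to compound 4 (within the scatter); a number 3 percentage points lower from compound 1 to compound 4 (within the scatter)). Among these four compounds, then, the unsubstituted phenyl of compound 4 cannot be told apart from the 4-carboxyphenyl, 4-(trifluoromethyl)phenyl or 3-fluorophenyl groups at this dose. No available evidence bears on this result.

The compounds shown leave open whether an amine or a hydroxyl group on this ring would move the number beyond the scatter.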